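The source may hold more compounds than are shown below. What is called first, only, known or untested is meant among the compounds shown, and "the series" means these compounds.

Measured in a functional assay on L1210 cells (Mus musculus) for inhibition, read by cell counting, with a stated time of 48 h; a lower number here means a stronger inhibitor, a higher number a weaker inhibitor:
compound 1 `CCN(CC)CN1C(=O)/C(=N/NC(=S)Nc2ccccc2)c2cc(Cl)ccc21`: 49000 nM
compound 2 `CCN(CC)CN1C(=O)/C(=N/NC(=S)Nc2ccc(Cl)cc2)c2ccccc21`: 11000 nM
compound 3 `CCN(CC)CN1C(=O)/C(=N/NC(=S)Nc2ccc(OC)cc2)c2ccccc21`: 2400 nM

Compound 3 holds the lowest number of the three in this assay, and compound 2 and compound 1 both lie beyond the scatter above it. Next is compound 4 `CCN(CC)CN1C(=O)/C(=N/NC(=S)Nc2ccccc2)c2ccccc21`, with hydrogen in place of methoxy on an aromatic carbon, para to a large group.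

Among the measured compounds shown here, only one measured step touches this carbon, a 4.6-fold lower number from compound 2 to compound 3 (0.66 log units; beyond the scatter), a modest change with methoxy in place of chloro. For the measured compounds named here, no measured pair isolates hydrogen against methoxy, so the direction is tentative. A modest move to a higher number is expected, a 2.9-fold higher number from compound 3 to compound 4 (0.46 log units; beyond the scatter). For compound 4 the estimated value is 7000 nM, with an expected range of 2500 nM to 20000 nM.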

Compound 4, half-maximal inhibitory concentration: 13000 nM
Estimate against measurement, compound 4: 1.9-fold (0.27 log units) below; low and high end bracket the measured number.
By their numbers in this assay, from the lowest: compound 3; then compounds 2 and 4 (each within the scatter of the next); then compound 1.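

In this assay, the unsubstituted phenyl gives this carbon a reference point: a 5.4-fold higher number from compound 3 to compound 4 (0.73 log units; beyond the scatter) ties the lower number to methoxy, not to substitution as such. With a 1.2-fold higher number from compound 2 to compound 4 (0.07 log units; within the scatter), within the scatter, chloro and hydrogen on this carbon cannot be told apart, and a 3.8-fold lower number from compound 1 to compound 4 (0.58 log units; beyond the scatter) shows that chloro on the core of compound 1 goes with a higher number. Nothing available explains these steps.

As far as these compounds go, whether the lower number extends to ethoxy, a longer alkoxy chain, hydroxyl or an amine on this carbon remains open. Also open, from the compounds shown here alone, is whether methoxy at this carbon would keep its step with chloro on the core.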